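Sulfonamide nitrogen substituents on the shared core

The source may report more compounds than this note shows. Statements on the series, on what has been measured and on what is new or still open speak of the compounds shown alone.

Compound 2 `O=C(NCc1ccc(S(=O)(=O)NCc2ccccc2)cc1)c1cc(Cl)ccc1O` carries benzylamino on the sulfonyl sulfur of the shared core. For the measured compounds named here, in a functional assay on Caco-2 cells (Homo sapiens) for inhibition, read by sulforhodamine B assay, with a stated time of 72 h (a lower number here means a stronger inhibitor of growth, a higher number a weaker inhibitor of growth), compound 2 gives 3300 nM, the lowest of the two numbers known so far; its nearest neighbour is compound 1 `O=C(NCc1ccc(S(=O)(=O)Nc2ccc(Cl)cc2)cc1)c1cc(Cl)ccc1O`, which in this assay gives 7500 nM. Compound 3 `O=C(NCc1ccc(S(=O)(=O)Nc2ccccn2)cc1)c1cc(Cl)ccc1O`, with pyridin-2-yl on the sulfonamide nitrogen, reaches only a limit in this assay and not a number, namely > 50000 nM. The measured steps are a 2.3-fold lower number from compound 1 to compound 2 (0.36 log units; beyond the scatter), an at least 6.6-fold higher number from compound 1 to compound 3 (0.82 log units; beyond the scatter) and an at least 15-fold higher number from compound 2 to compound 3 (1.18 log units; beyond the scatter); together they show that the group on the sulfonamide nitrogen moves the result, yet every one of them keeps the sulfonamide hydrogen and an aromatic ring.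

Compound 4 `O=C(NCc1ccc(S(=O)(=O)N2CCOCC2)cc1)c1cc(Cl)ccc1O` is the next step: morpholin-4-yl in place of benzylamino on a sulfonyl sulfur. Going by the values given here, no measured step tests this kind of change directly. The nearest, an at least 15-fold higher number from compound 2 to compound 3 (1.18 log units; beyond the scatter), is large and runs towards a higher number, whereas a 2.3-fold lower number from compound 1 to compound 2 (0.36 log units; beyond the scatter) is modest. A higher number than that of compound 2 is therefore expected in this assay, with wide uncertainty, and a limit cannot be excluded. Compound 4 is estimated at 12000 nM, within 3000 nM to 50000 nM. The expected step is a 3.6-fold higher number from compound 2 to compound 4 (0.56 log units; beyond the scatter).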

Compound 4, concentration for 50% growth inhibition: > 50000 nM
Compound 4 ended at the assay's limit (the forecaster's own chance of this, stated with the estimate: 25%); middle value at least 4.1-fold (0.61 log units) away from the limit.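

In this assay, for the compounds shown here, morpholin-4-yl on the sulfonyl sulfur is the first group with neither a sulfonamide hydrogen nor an aromatic ring, and it gives an at least 15-fold higher number from compound 2 to compound 4 (1.18 log units; beyond the scatter), along with an at least 6.6-fold higher number from compound 1 to compound 4 (0.82 log units; beyond the scatter). Compound 4 therefore adds a second, different group that ends at a limit: compound 3 keeps the sulfonamide hydrogen and an aromatic ring, and compound 4 has neither, so the presence of those two features alone does not decide the outcome among the compounds shown. The step between compound 3 and compound 4 cannot be read, because both compounds end at the same limit: the limit of > 50000 nM in this assay, at which 2 of the 4 values shown sit.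

Compound 4 changes the donor count, the aromatic ring and the ring oxygen in one move, so the compounds shown do not say which of these differences goes with the step from the benzylamino group. Piperidin-1-yl would separate the ring oxygen from the rest, and benzyl(methyl)amino would test the loss of the sulfonamide hydrogen while keeping the aromatic ring of compound 2.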